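This account rests on a few compounds, and the source may have more. Where it says the series, first, only, none or still open, it means among the compounds named here.

Measured compounds in a functional assay on cells for antagonist activity at Free fatty acid receptor 1 (Homo sapiens), read by TR-FRET and inositol phosphate accumulation, with a stated time of 2 h (a lower number here means a stronger inhibitor, a higher number a weaker inhibitor), so far:

Compound 1 `COc1ccccc1OCc1cc(C)nc(-c2ccccn2)n1` gives 2000 nM.
Compound 2 `Cc1cc(COc2ccccc2F)nc(-c2ccccn2)n1` gives 398 nM.
Compound 3 `Cc1cc(COc2cccc(F)c2)nc(-c2ccccn2)n1` gives 794 nM.

Going by the values given here, compound 2 holds the lowest number of the three, though its gap to compound 3 is within the usual scatter, so only the step of a 5.0-fold lower number from compound 1 to compound 2 (0.70 log units; beyond the scatter) sets it apart from the rest. The new compound 4 `Cc1cc(COc2ccc(F)cc2F)nc(-c2ccccn2)n1` keeps everything in compound 2 and adds one group: fluoro in place of hydrogen on an aromatic carbon. Among the compounds with values here, two measured steps bear on this: the exchange a 5.0-fold lower number from compound 1 to compound 2 (0.70 log units; beyond the scatter), which was modest, and the shift a 2.0-fold higher number from compound 2 to compound 3 (0.30 log units; within the scatter), which stayed within the scatter. Neither step adds a fluoro to a ring already carrying one, so no firm direction follows. Compound 4 is therefore expected to sit near compound 2, with a step of a 1.0-fold higher number from compound 2 to compound 4 (0.00 log units; within the scatter) not beyond the scatter. The estimate for compound 4 in this assay is 400 nM, expected between 160 nM and 1000 nM.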

Compound 4, half-maximal inhibitory concentration: 398 nM
Beside the measured number, compound 4's estimate is 1.0-fold (0.00 log units) above it; the range from low to high includes it.
By their numbers in this assay, from the lowest: compounds 2, 4 and 3 (each within the scatter of the next); then compound 1.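

Adding a fluoro on an aromatic carbon, meta to a fluoro group and para to a large group, gives no change at the digits printed from compound 2 to compound 4 (within the scatter) in this assay. Going by these compounds alone, this position therefore takes a second fluoro with no change beyond the scatter, which the earlier compounds, each with no more than one fluoro on that ring, could not show. Nothing measured here explains this outcome. The compounds shown leave open whether a chloro, a trifluoromethyl or an amine at this same position would also leave the number unmoved.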